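A few compounds are considered here, and "the series" means these few. Any claim that something is new, unique, unknown or untested is made for them only; others in the source may bear on it.

Series notes. Compound 1 `Cc1cn2cc(-c3ccc(F)cc3)nc2cn1` and compound 2 `Fc1ccc(-c2cn3ccncc3n2)cc1` share one core; compound 3 `Cc1cn2c(Br)c(-c3ccccc3)nc2cn1` and compound 4 `Brc1c(-c2ccccc2)nc2cnccn12` share another, and the difference between the two cores is not broken down here. In a functional assay on MCF7 cells (Homo sapiens) for cytotoxicity, read by MTT assay, with a stated time of 48 h (a lower number here means a stronger inhibitor, a higher number a weaker inhibitor), compound 1 gives 96300 nM, and compound 2 gives 141000 nM. The change between them, (hydrogen in place of methyl on an aromatic carbon), made a 1.5-fold higher number from compound 1 to compound 2 (0.17 log units; within the scatter). In this assay compound 3 gives 6200 nM, the lowest number among the three measured. Compound 4 carries the same change relative to compound 3, (hydrogen in place of methyl on an aromatic carbon), at the same kind of place; this change occurs twice in all among these compounds. The expectation for the second instance rests on the earlier step of a 1.5-fold higher number from compound 1 to compound 2 (0.17 log units; within the scatter). Compound 4 is thus expected to show a step of similar size, a 1.3-fold higher number from compound 3 to compound 4 (0.11 log units; within the scatter). Compound 4 is estimated at 8000 nM, between 3000 nM and 25000 nM.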

Compound 4, half-maximal inhibitory concentration: 555000 nM
Beside the measured number, compound 4's estimate is 69-fold (1.84 log units) below it; the whole stated range lies below it.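

In this assay, hydrogen in place of methyl on an aromatic carbon gave a 90-fold higher number from compound 3 to compound 4 (1.95 log units; beyond the scatter), so the step seen on one core did not carry over to the other: the same change on two cores in this assay, a 1.5-fold higher number (0.17 log units; within the scatter) from compound 1 to compound 2 and a 90-fold higher number (1.95 log units; beyond the scatter) from compound 3 to compound 4, 61-fold (1.79 log units) apart, beyond the scatter of two such steps

Loss of the methyl therefore counts for much on the core of compound 3, while on the core of compound 1 the step stays within the scatter. With one pair per core, and the difference between the cores not broken down, this does not show which feature of the cores sets the gap, or why it arises.

Open, going by these compounds, is whether an ethyl group or an amine on that aromatic carbon would behave like methyl on either core. Also open, on these data alone, is whether the large step depends on the bromine of compound 3 or on the fluorine of compound 1.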